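Hydroxy in Place of Piperidinyl on the Side Chain

This account rests on a few compounds, and the source may have more. Where it says the series, first, only, none or still open, it means among the compounds named here.

Compound 1 `Cn1ncc(Cl)c1-c1cc(C(=O)NC2CNCC2c2ccc(C(F)(F)F)cc2)oc1Cl`: 538 nM
Compound 2 `Cn1ncc(Cl)c1-c1cc(C(=O)N[C@@H]2CN[C@H](CCN3CCCCC3)C[C@H]2c2ccc(Cl)c(Cl)c2)oc1Cl`: 5.65 nM

Of the two compounds measured in an assay for inhibition of RAC-alpha serine/threonine-protein kinase (Homo sapiens), read by HTRF, with a stated time of 1 h (on this read-out lower numbers stand for stronger inhibition and higher numbers for weaker inhibition), compound 2 gives the lowest number; compound 1 stands far above it, beyond the usual scatter. Compound 3 `Cn1ncc(Cl)c1-c1cc(C(=O)N[C@@H]2CN[C@H](CCO)C[C@H]2c2ccc(Cl)c(Cl)c2)oc1Cl` differs from compound 2 by hydroxy in place of piperidin-1-yl on a saturated chain carbon, two bonds along the chain from a saturated ring carbon. Going by the values given here, no measured pair shows this change, so the step remains uncertain. A modest weakening is expected, with the step from compound 2 to compound 3 estimated at a 3.5-fold higher number from compound 2 to compound 3 (0.55 log units; beyond the scatter), near the edge of the scatter. For compound 3 the estimated value is 20 nM, with a range from 5 nM to 80 nM.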

Compound 3, half-maximal inhibitory concentration: 2.74 nM
Estimate against measurement, compound 3: 7.3-fold (0.86 log units) above; measured number below the stated range.
By their numbers in this assay, from the lowest: compound 3; then compound 2; then compound 1.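

In this assay, the piperidin-1-yl group proves dispensable at this position: hydroxy in its place, on a saturated chain carbon, two bonds along the chain from a saturated ring carbon, brings a 2.1-fold lower number from compound 2 to compound 3 (0.31 log units; beyond the scatter). The step is modest, but it shows that the ring and its nitrogen can leave the chain with no loss on this read-out. No measurement offered here explains the step. The compounds shown leave open how dimethylamino, a carboxylic acid or a longer chain ending in hydroxy would read at this place, and whether a plain ethyl chain would match 2-hydroxyethyl.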